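Fluoro added to the benzyl ring of compound 2

The source may report more compounds than this note shows. Statements on the series, on what has been measured and on what is new or still open speak of the compounds shown alone.

Two compounds sharing one core have numbers in an assay on isolated protein for displacement of a labelled ligand from Orexin/Hypocretin receptor type 1 (Homo sapiens), with a stated time of 90 min; on this read-out lower numbers stand for stronger inhibition and higher numbers for weaker inhibition. Compound 1 `COc1cc(F)c(CN2C(=O)N(c3ccc(OC)c(OC)c3)S(=O)(=O)c3ccccc32)c(Cl)c1` gives 0.398 nM. Compound 2 `COc1ccc(N2C(=O)N(Cc3c(F)cccc3Cl)c3ccccc3S2(=O)=O)cc1OC` gives 7.94 nM, the higher of the two numbers, with a 20-fold higher number from compound 1 to compound 2 (1.30 log units; beyond the scatter). Compound 3 `COc1ccc(N2C(=O)N(Cc3c(F)cc(F)cc3Cl)c3ccccc3S2(=O)=O)cc1OC` differs from compound 2 by fluoro in place of hydrogen on an aromatic carbon. Within the data shown here, no measured step concerns a change on that ring; the only step known, from compound 1 to compound 2, lies on the other aryl group and does not bear on this one. For compound 3 the expectation is therefore a step of a 1.3-fold lower number from compound 2 to compound 3 (0.10 log units; within the scatter), within the scatter, giving an estimated 6.3 nM with a range of 1.6 nM to 25 nM.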

Compound 3, inhibition constant: 25.1 nM
For compound 3 the middle estimate is 4.0-fold (0.60 log units) below the measured one; measured number outside the range, above it.
By their numbers in this assay, from the lowest: compound 1; then compound 2; then compound 3.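

On the ring para to a large group, this position responds to more than methoxy: in this assay, fluoro in place of hydrogen gives a 3.2-fold higher number from compound 2 to compound 3 (0.50 log units; beyond the scatter) and does not match hydrogen. Replacing methoxy with fluoro gives a 63-fold higher number from compound 1 to compound 3 (1.80 log units; beyond the scatter), so the order from the lowest number is methoxy, hydrogen, fluoro across compound 1, compound 2 and compound 3. No evidence on hand accounts for this order. Still open, as far as these compounds go, is how an amine, a carboxylic acid or a longer ethoxy chain at this position would compare with methoxy.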